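A 1H-1,2,4-triazol-1-yl group replaces methylamino in compound 3

The compounds below may be only part of what the source reports. "The series", "measured", "known", "first", "only" and "open" are said of these compounds alone.

In an ADME assay on microsomes from liver (Rattus norvegicus) for metabolic stability (on this read-out higher numbers stand for fast clearance and lower numbers for slow clearance), compound 3 (`CNc1nc(NC)nc(NC2(C#N)CCCCC2)n1`) gives 210 mL/min/kg as the highest of the three numbers at hand. Compound 2 (`CNc1nc(NC2(C#N)CCCCC2)nc(-n2cccn2)n1`) gives 103 mL/min/kg and lies nearest to it, while compound 1 (`CNc1nc(NC2(C#N)CCCC(C)C2)nc(-n2cncn2)n1`) gives 96 mL/min/kg and lies furthest, both gaps being beyond the scatter. Compound 4 (`CNc1nc(NC2(C#N)CCCCC2)nc(-n2cncn2)n1`) is not yet measured. It differs from compound 3 by 1H-1,2,4-triazol-1-yl in place of methylamino on an aromatic carbon opposite the ring nitrogen. The closest measured step runs the other way: methylamino in place of 1H-pyrazol-1-yl gave a 2.0-fold higher number from compound 2 to compound 3 (0.31 log units; beyond the scatter) and this modest step lies beyond the scatter. Compound 1 also carries 1H-1,2,4-triazol-1-yl and sits at 96 mL/min/kg in the same range as compound 2. A similar modest fall is therefore expected. The expected change is a 2.1-fold lower number from compound 3 to compound 4 (0.32 log units; beyond the scatter) in this assay on this reasoning. For compound 4 the estimated value is 100 mL/min/kg within an expected range of 60 mL/min/kg to 165 mL/min/kg on this estimate.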

Compound 4, clearance: 52 mL/min/kg
For compound 4 the middle estimate is 1.9-fold (0.28 log units) above the measured one, outside the stated range (below it).
By their numbers in this assay, from the lowest: compounds 4, 1 and 2 (each within the scatter of the next); then compound 3.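

In this assay, 1H-1,2,4-triazol-1-yl in place of methylamino on this aromatic carbon gives a 4.0-fold lower number from compound 3 to compound 4 (0.61 log units; beyond the scatter), a direct reading of this change with the rest of the molecule held the same. Set against 1H-pyrazol-1-yl, the group gives a 2.0-fold lower number from compound 2 to compound 4 (0.30 log units; within the scatter), so these two five-membered aromatic rings cannot be told apart at this position in this assay. The methyl on the saturated ring also makes no readable difference, with hydrogen in its place giving a 1.8-fold lower number from compound 1 to compound 4 (0.27 log units; within the scatter).

Nothing at hand gives a reason for the size of these steps. As far as these compounds go, it remains open how an imidazol-1-yl group, a morpholine or a dimethylamino group on this aromatic carbon would compare with 1H-1,2,4-triazol-1-yl.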